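Thiophen-3-yl in Place of Trifluoromethyl on a Shared Core

The source may hold more compounds than are shown below. What is called first, only, known or untested is meant among the compounds shown, and "the series" means these compounds.

Compound 1 `Brc1ccc2ccn(CCN3CCN4CCCCC4C3)c2c1`: 78%
Compound 2 `CN1CCCN(CCn2ccc3ccc(C(F)(F)F)cc32)CC1`: 89%

Both compounds were tested in an assay on HEK293 cells for binding affinity to 5-hydroxytryptamine receptor 7 (Homo sapiens), read by radioligand binding, tested at 1 uM; on this read-out higher numbers stand for more inhibition at the one concentration tested (going by the name of the read-out) and lower numbers for less inhibition. Compound 2 stands highest of the two numbers: in this assay compound 2 gives 89%, while its nearest neighbour, compound 1, gives 78%, a gap beyond the usual scatter. The two differ in more than one place, so their pair tells nothing about any single change.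

Compound 3 `CN1CCCN(CCn2ccc3ccc(-c4ccsc4)cc32)CC1` has not yet been measured. It differs from compound 2 in one place: thiophen-3-yl in place of trifluoromethyl on an aromatic carbon. Within the data shown here, no measured pair shows this change, so there is no step to go by. The account therefore expects no step beyond the scatter, with the step from compound 2 to compound 3 estimated at a number 5 percentage points lower from compound 2 to compound 3 (within the scatter), allowing for some downward drift. In this assay compound 3 is expected to give about 84%, within a range from 62% to 98%.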

Compound 3, a percentage reported as inhibition, at one concentration (the size of the read-out at that concentration, not a potency): 68%
For compound 3 the middle estimate is 16 percentage points above the measured one; measured number inside the range.
By their numbers in this assay, from the lowest: compounds 3 and 1 (each within the scatter of the next); then compound 2.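

On this aromatic carbon, thiophen-3-yl in place of trifluoromethyl gives in this assay a result a number 21 percentage points lower from compound 2 to compound 3 (beyond the scatter), the first evidence from a single change that the group at this position affects the read-out. Even so, compound 3 gives 68% at the one concentration tested, so a five-membered aromatic ring here does not abolish inhibition. No measurement at hand accounts for the difference between the two groups.

The compounds shown leave open whether a nitrile, an amine or a chlorine atom on the same carbon would stay close to compound 2 or fall as far as compound 3. Among these compounds, this change appears in only one pair, so it also remains open whether it would give a step of similar size with the side chain of compound 1.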